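Compound 3 to compound 4: a new aryl group on the amide

The compounds below may be only part of what the source reports. "The series", "measured", "known", "first", "only" and "open" are said of these compounds alone.

In a functional assay on U-251 cells (Homo sapiens) for inhibition, read by MTT assay, with a stated time of 2 days (on this read-out higher numbers stand for weaker inhibition of growth and lower numbers for stronger inhibition of growth), compound 1 `Nc1ccccc1NC(=O)CCCNCC(=O)Nc1ccc(Cl)cc1` gives 75000 nM and compound 2 `Nc1ccccc1NC(=O)CCCNCC(=O)Nc1ccc(Br)cc1` gives 80000 nM. Compound 3 `Nc1ccccc1NC(=O)CCCNCC(=O)Nc1cc(Cl)ccc1Cl` gives > 100000 nM, which is a limit of the assay and not a number.

Compound 4 `COc1ccc(NC(=O)CNCCCC(=O)Nc2ccccc2N)cc1` carries 4-methoxyphenyl in place of 2,5-dichlorophenyl on an amide-type nitrogen.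

Among the measured compounds shown here, no measured step involves 4-methoxyphenyl, so the evidence is indirect. Exchanging the halogen gives a 1.1-fold higher number from compound 1 to compound 2 (0.03 log units; within the scatter), within the scatter. The two steps that change the aryl group give an at least 1.3-fold higher number from compound 1 to compound 3 (0.12 log units; that floor lies within the scatter) and an at least 1.2-fold higher number from compound 2 to compound 3 (0.09 log units; that floor lies within the scatter), and each of these floors lies within the scatter. On that basis, no step beyond the scatter is expected in this assay, although a small move to a lower number remains possible. The expected step, read against a limit, is an at least 1.2-fold lower number from compound 3 to compound 4 (0.09 log units; that floor lies within the scatter). Compound 4 is estimated at 80000 nM, with an expected range of 40000 nM to 140000 nM.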

Compound 4, concentration for total growth inhibition: > 100000 nM
Compound 4 gave a limit, no number (the forecaster's own chance of this, stated with the estimate: 35%); at least 1.2-fold (0.09 log units) between middle value and limit.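

In this assay compound 4 gives > 100000 nM, which is a limit of the assay, so 4-methoxyphenyl on this amide-type nitrogen, with 1 hydrogen-bond acceptor where 2,5-dichlorophenyl has 0, does not bring a number back into range. Methoxy in place of bromo gives an at least 1.2-fold higher number from compound 2 to compound 4 (0.09 log units; that floor lies within the scatter), and methoxy in place of chloro gives an at least 1.3-fold higher number from compound 1 to compound 4 (0.12 log units; that floor lies within the scatter), so neither halogen compound is separated from the methoxy compound beyond the scatter. The step between the two limits cannot be read, and the limit now holds for two different aryl groups: the limit of > 100000 nM in this assay, at which 2 of the 4 values shown sit.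

Open, on these data alone, is whether a benzyl group on this amide-type nitrogen, or a longer chain in the shared core, would give a step beyond the scatter in this assay.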